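Methylating a Phenolic Hydroxy Group in a Chalcone Series

The compounds below may be only part of what the source reports. "The series", "measured", "known", "first", "only" and "open" are said of these compounds alone.

Measured so far:
compound 1, `COc1cc(/C=C/C(=O)c2cccc(O)c2)ccc1O`, gives 62.6%;
compound 2, `COc1ccc(OC)c(CCC(=O)c2cccc(O)c2)c1`, gives 93.6%.

In an ADME assay on RAW264.7 cells (Mus musculus) for cytotoxicity, read by MTT assay, with a stated time of 24 h, tested at 10 ug/mL (on this read-out higher numbers stand for a weaker effect at the one concentration tested and lower numbers for a stronger effect), compound 1 stands lowest of the two numbers, with compound 2 lying higher by a margin beyond the usual scatter. Compound 3, `COc1ccc(/C=C/C(=O)c2cccc(O)c2)cc1OC`, is not yet measured. It differs from compound 1 by methyl in place of hydrogen on an oxygen on an aromatic ring. Among the compounds with values here, no step between measured compounds bears on this change, so the expectation rests on compound 1 alone: the step is expected to be small, at most a modest rise, and may not exceed the scatter. The expected step is a number 7.4 percentage points higher from compound 1 to compound 3 (within the scatter). Compound 3 is therefore estimated at 70%, within 50% to 90%.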

Compound 3, a percentage reported as activity, at one concentration (the size of the read-out at that concentration, not a potency): 63.9%
Compound 3: middle estimate off by 6.1 percentage points, on the high side; measured number inside the range.
By their numbers in this assay, from the lowest: compounds 1 and 3 (each within the scatter of the next); then compound 2.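

In this assay, within the data shown here, replacing hydroxy with methoxy on an oxygen on an aromatic ring gives a number 1.3 percentage points higher from compound 1 to compound 3 (within the scatter), the first direct reading of this change. At this position, the hydrogen on that oxygen can therefore be replaced by methyl without a step beyond the scatter in this read-out. Nothing measured here explains why compound 1 and compound 3 read alike.

From the compounds shown here alone, it remains open whether a longer chain on this oxygen, such as ethoxy, would read the same. An amine in place of the methoxy is equally untested among the compounds shown.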